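A few compounds are considered here, and "the series" means these few. Any claim that something is new, unique, unknown or untested is made for them only; others in the source may bear on it.

Compound 3, `O=C(Nc1ccc(Cl)cc1)c1cc(Oc2ccc(/C=C/c3ccncc3)cc2)ccn1`, is the compound of this series with the highest number shown in a functional assay on HepG2 cells (Homo sapiens) for antiproliferative activity, read by CCK-8 assay, with a stated time of 48 h; a higher number here means a weaker inhibitor, a lower number a stronger inhibitor: compound 3 gives 56200 nM. Its nearest neighbour is compound 1, `O=C(Nc1ccc(Cl)cc1)c1cc(Oc2ccc(/C=C/c3ccccn3)cc2)ccn1`, which in this assay gives 31300 nM; the change a 1.8-fold higher number from compound 1 to compound 3 (0.25 log units; within the scatter) stays within the scatter. Compound 2, `CC(C)NC(=O)c1cc(Oc2ccc(/C=C/c3ccccn3)cc2)ccn1`, reaches only a limit in this assay, at > 100000 nM. Among the compounds with values here, the step of an at least 3.1-fold higher number from compound 1 to compound 2 (0.50 log units; beyond the scatter) is the one that touches the amide side of the molecule, and it is the only measured step that bears on the change now in view.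

Compound 4, `O=C(c1cc(Oc2ccc(/C=C/c3ccncc3)cc2)ccn1)N1CCCC1`, differs from compound 3 in exactly this part: pyrrolidin-1-yl in place of (4-chlorophenyl)amino on a carbonyl carbon. Because an at least 3.1-fold higher number from compound 1 to compound 2 (0.50 log units; beyond the scatter) was at least modest when the 4-chlorophenyl group was exchanged at the amide nitrogen, a further loss is expected here, a 2.1-fold higher number from compound 3 to compound 4 (0.33 log units; beyond the scatter), in the direction of a weaker inhibitor. Given (the limit of > 100000 nM in this assay, at which 1 of the 3 values shown sits), the assay may well report only a limit. Compound 4 is therefore estimated at 120000 nM, in a range from 45000 nM to 320000 nM.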

Compound 4, half-maximal inhibitory concentration: 41600 nM
Estimate against measurement, compound 4: 2.9-fold (0.46 log units) above; measured number outside the range, below it.
By their numbers in this assay, from the lowest: compounds 1, 4 and 3 (each within the scatter of the next). At a limit, above all of these: compound 2.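

At this carbonyl carbon, the (4-chlorophenyl)amino group, with its aromatic ring and amide hydrogen, gives way to pyrrolidin-1-yl with no change that stands clear of the scatter in this assay (a 1.4-fold lower number from compound 3 to compound 4 (0.13 log units; within the scatter)). Removing the 4-chlorophenyl group therefore does not always cost activity here, as the earlier step (an at least 3.1-fold higher number from compound 1 to compound 2 (0.50 log units; beyond the scatter)) alone might have suggested, although the two steps differ in both the entering group and the pyridinyl group, so they cannot be set directly against each other. Within the data shown here, compound 2 remains the only compound at a limit: the limit of > 100000 nM in this assay, at which 1 of the 4 values shown sits.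

As far as these compounds go, whether pyrrolidin-1-yl behaves the same way with the pyridin-2-yl group remains open. So does whether a piperidin-1-yl group, a morpholin-4-yl group or a free carboxylic acid at this carbonyl carbon would separate from these values.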